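Tetrazole attachment in a cysteinyl leukotriene antagonist series

The compounds below may be only part of what the source reports. "The series", "measured", "known", "first", "only" and "open" are said of these compounds alone.

Measured compounds:
compound 1 `CCCc1c(COc2ccc(-c3nn[nH]n3)cc2)ccc(C(C)=O)c1O`: 10 nM
compound 2 `CCCc1c(COc2ccc(Cc3nnn[nH]3)cc2)ccc(C(C)=O)c1O`: 10 nM
compound 3 `CCCc1c(COCCOc2ccc(-c3nn[nH]n3)cc2)ccc(C(C)=O)c1O`: 50.1 nM

All three were tested in a functional assay on ileum (Cavia porcellus) for inhibition of cysteinyl leukotriene receptor (Homo sapiens); a lower number here means a stronger inhibitor, a higher number a weaker inhibitor. Compound 1 gives 10 nM and compound 2 gives 10 nM, so the step of no change at the digits printed from compound 1 to compound 2 (within the scatter) is within the scatter; the change between them is (1H-tetrazol-5-yl)methyl in place of 2H-tetrazol-5-yl on an aromatic carbon. Compound 3 gives 50.1 nM, the highest number of the three; the difference between the core of compound 3 and the core of compound 1 is not broken down here, as the two differ in more than one place.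

The unmeasured compound 4 `CCCc1c(COCCOc2ccc(Cc3nnn[nH]3)cc2)ccc(C(C)=O)c1O` carries the same change relative to compound 3: (1H-tetrazol-5-yl)methyl in place of 2H-tetrazol-5-yl on an aromatic carbon. The place description is the same word for word as for the step from compound 1 to compound 2, so this is the same change, made a second time on a different core. On the first core it moved the number not at all beyond the scatter, as no change at the digits printed from compound 1 to compound 2 (within the scatter) shows. There is one such precedent only, and nothing more about compound 4 is known.

Compound 4 is therefore expected to sit close to compound 3 in this assay, with an expected step of a 1.0-fold lower number from compound 3 to compound 4 (0.00 log units; within the scatter) that rests on compound 1 and compound 2 and their step of no change at the digits printed from compound 1 to compound 2 (within the scatter). The estimate for compound 4 is 50 nM, expected to fall between 20 nM and 125 nM.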

Compound 4, half-maximal inhibitory concentration: 100 nM
Estimate against measurement, compound 4: 2.0-fold (0.30 log units) below, within the range that was stated.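

In this assay, placing (1H-tetrazol-5-yl)methyl where 2H-tetrazol-5-yl stood on the second core gives a 2.0-fold higher number from compound 3 to compound 4 (0.30 log units; within the scatter), and the two steps for this change do not differ: the same change on two cores in this assay, no change at the digits printed (within the scatter) from compound 1 to compound 2 and a 2.0-fold higher number (0.30 log units; within the scatter) from compound 3 to compound 4, 2.0-fold (0.30 log units) apart, within the scatter of two such steps. On the two cores shown, the change therefore carries across without a step beyond the scatter, and the precedent from the first core held on the second. This does not show that the change is neutral across the series: it rests on two pairs of compounds in a single assay, and steps within the scatter can neither establish nor exclude a small real shift, so the difference between the two steps should not be read as a core-dependent effect.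

The compounds shown leave open whether a longer chain carrying the tetrazole, such as (1H-tetrazol-5-yl)ethyl, would also stay within the scatter on these cores. They also leave open how a carboxylic acid in place of the tetrazole would behave on either core, and whether any of these steps holds on a core with a different group in place of the propyl chain.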